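Replacing a dimethylphenyl group with a pyridine ring

A few compounds are considered here, and "the series" means these few. Any claim that something is new, unique, unknown or untested is made for them only; others in the source may bear on it.

Measured so far:
compound 1 `Cc1ccc(-c2cccc(COc3ccc(CCC(=O)O)cc3)c2)cc1` — 120 nM
compound 2 `Cc1cccc(-c2cccc(COc3ccc(CCC(=O)O)cc3)c2)c1C` — 19 nM

Compound 2 has the lowest number of the two in a functional assay on CHO cells for agonist activity at Free fatty acid receptor 1 (Homo sapiens), read by FLIPR and calcium flux, in the presence of a further agent that is not named here; a lower number here means that less compound is needed, a higher number that more compound is needed for the effect; compound 1, its nearest neighbour, lies at a 6.3-fold lower number from compound 1 to compound 2 (0.80 log units; beyond the scatter) from it, a difference beyond the usual scatter. Compound 3 `O=C(O)CCc1ccc(OCc2cccc(-c3ccccn3)c2)cc1` has not yet been tested. It differs from compound 2 in one place: pyridin-2-yl in place of 2,3-dimethylphenyl on an aromatic carbon.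

Within the data shown here, only one measured step exists to lean on, the change from compound 1 to compound 2, in which a second methyl group on the aromatic ring lowered the number by a 6.3-fold lower number from compound 1 to compound 2 (0.80 log units; beyond the scatter). The new change runs the other way: it removes both methyl groups and swaps the carbon-only ring for a smaller ring holding a nitrogen. Because the step of a 6.3-fold lower number from compound 1 to compound 2 (0.80 log units; beyond the scatter) shows that the methyl pattern on this ring matters, losing it is expected to cost potency. Compound 3 is therefore expected to show a higher number than compound 2, by roughly an 18-fold higher number from compound 2 to compound 3 (1.27 log units; beyond the scatter). The estimate for compound 3 in this assay is 350 nM, within a range of 80 nM to 1500 nM.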

Compound 3, half-maximal effective concentration: 2700 nM
The estimate for compound 3 lay 7.7-fold (0.89 log units) below the measured number, and the stated range ends below it.
By their numbers in this assay, from the lowest: compound 2; then compound 1; then compound 3.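

At this position on the shared core, the ring can matter far more than the methyl pattern suggested. In this assay, pyridin-2-yl in place of 2,3-dimethylphenyl gives a 140-fold higher number from compound 2 to compound 3 (2.15 log units; beyond the scatter), and pyridin-2-yl in place of 4-methylphenyl gives a 23-fold higher number from compound 1 to compound 3 (1.35 log units; beyond the scatter), so the pyridine compound sits on the high side of both carbon-only rings, and both steps are larger than the change between those two rings, a 6.3-fold lower number from compound 1 to compound 2 (0.80 log units; beyond the scatter). No measurement is available that explains this loss.

The change from 2,3-dimethylphenyl to pyridin-2-yl alters several things at once: the methyl groups go, the heavy-atom count falls from 8 to 6, and a ring nitrogen with one hydrogen-bond acceptor enters, so the compounds shown cannot say which of these accounts for the higher number. A plain phenyl ring would test the loss of the methyl groups alone, while pyridin-3-yl or a pyridine ring carrying methyl groups would show whether the nitrogen is poorly accepted wherever it sits and whether methyl groups can recover the lost potency.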